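Swapping Carboxy for Trifluoromethoxy: What to Expect

A few compounds are considered here, and "the series" means these few. Any claim that something is new, unique, unknown or untested is made for them only; others in the source may bear on it.

Going by the values given here, in an assay on isolated protein for inhibition of 2-Hydroxyacid oxidase 2 (Homo sapiens), tested at 10 uM (on this read-out higher numbers stand for a stronger effect at the one concentration tested and lower numbers for a weaker effect), compound 1 `Cc1n[nH]c(C(=O)O)c1Cc1cccc(-c2cccc(F)c2)c1` gives 50%, while compound 2 `Cc1n[nH]c(C(=O)O)c1Cc1cccc(C(=O)O)c1` gives 0%, the lower of the two numbers measured so far. Among the compounds with values here, the single step measured, a number 50 percentage points lower from compound 1 to compound 2 (beyond the scatter), shows a large loss when carboxy arrives. Compound 3 `Cc1n[nH]c(C(=O)O)c1Cc1cccc(OC(F)(F)F)c1` differs from compound 2 by trifluoromethoxy in place of carboxy on an aromatic carbon. Because compound 2 sits at 0% and the drop a number 50 percentage points lower from compound 1 to compound 2 (beyond the scatter) came with carboxy, removing carboxy is expected to recover part of that loss, an estimated a number 25 percentage points higher from compound 2 to compound 3 (beyond the scatter) change. Compound 3 is therefore estimated at 25%, expected to fall between 0% and 55%.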

Compound 3, a percentage reported as inhibition, at one concentration (the size of the read-out at that concentration, not a potency): 26%
The estimate for compound 3 lay 1 percentage points below the measured number; measured number inside the range.
By their numbers in this assay, from the lowest: compound 2; then compound 3; then compound 1.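

With trifluoromethoxy in place of carboxy, a number 26 percentage points higher from compound 2 to compound 3 (beyond the scatter) in this assay shows that the carboxy result does not hold for every group on this aromatic carbon. Against the 3-fluorophenyl, trifluoromethoxy still shows a number 24 percentage points lower from compound 1 to compound 3 (beyond the scatter) so among these compounds, the group without a ring keeps only part of the effect. Nothing measured here gives a reason for either step. On these data alone, whether the hydrogen-bond donor that leaves with carboxy matters remains open. A methoxy group or an amine on this carbon could help to tell.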